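A few compounds are considered here, and "the series" means these few. Any claim that something is new, unique, unknown or untested is made for them only; others in the source may bear on it.

Measured so far in an assay for binding affinity to Alpha-1B adrenergic receptor (Homo sapiens); a higher number here means a weaker inhibitor, a lower number a stronger inhibitor:

compound 1, `O=c1c2ccccc2c(Cc2ccc(Cl)cc2)nn1CCNCCCCc1ccc(OCCCN2CCCCCC2)cc1`: 316 nM
compound 2, `CN1CCC[C@@H]1Cn1nc(CC2CCCCC2)c2ccccc2c1=O`: > 1990 nM
compound 3, `O=c1c2ccccc2c(Cc2ccc(Cl)cc2)nn1C[C@H]1CCCN1CCCCCc1ccc(OCCCN2CCCCCC2)cc1`: 50.1 nM

Compound 2 stands apart on the numbers shown. The value of compound 2 is a limit of the assay and not a number, and the limit of > 1990 nM in this assay, at which 1 of the 3 values shown sits, marks where it sits. Compound 1 and compound 3 both give numbers rather than limits; each carries a 4-chlorobenzyl group and a long tail on the shared core, whereas compound 2 carries a cyclohexylmethyl group and only a short substituent.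

Compound 4, `CN1CCC[C@@H]1Cn1nc(Cc2ccc(F)cc2)c2ccccc2c1=O`, differs from compound 2 by 4-fluorophenyl in place of cyclohexyl on a saturated chain carbon bound to an aromatic carbon. For the measured compounds named here, no measured pair in the set isolates this change, so the size of the step can only be guessed. Compound 1 and compound 3 show that an aryl group on that saturated chain carbon occurs in compounds with measurable numbers, but those two also carry the long tail that compound 4 lacks, so they cannot be read as a step for this change. The step from compound 2 to compound 4 is expected to be modest and toward a stronger inhibitor, possibly not beyond the scatter; the expected step is an at least 1.3-fold lower number from compound 2 to compound 4 (0.12 log units; that floor lies within the scatter). Compound 4 is expected to give about 1500 nM in this assay, between 400 nM and 6000 nM.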

Compound 4, inhibition constant: 79.4 nM
The estimate for compound 4 lay 19-fold (1.28 log units) above the measured number, outside the stated range (below it).
By their numbers in this assay, from the lowest: compounds 3 and 4 (each within the scatter of the next); then compound 1. At a limit, above all of these: compound 2.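

In this assay, 4-fluorophenyl in place of cyclohexyl on a saturated chain carbon bound to an aromatic carbon gives an at least 25-fold lower number from compound 2 to compound 4 (1.39 log units; beyond the scatter), so this position responds strongly to the cyclohexylmethyl to 4-fluorobenzyl change. The value of compound 2 is a limit of the assay and not a number: the limit of > 1990 nM in this assay, at which 1 of the 4 values shown sits. Compound 4 gives 79.4 nM while carrying only the short substituent, so a number in this assay no longer appears solely among compounds with the long tail.

The compounds shown leave open whether the step belongs to the aromatic ring or to the fluorine, and an unsubstituted benzyl group at this place would separate the two. Also open, going by these compounds, is how a 4-chlorobenzyl group would read on the short substituent, and whether the long tail changes the number of a compound that carries a 4-fluorobenzyl group.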